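The source may hold more compounds than are shown below. What is called first, only, known or untested is meant among the compounds shown, and "the series" means these compounds.

Measured compounds:
- Compound 1, `NC(=O)c1c(NC(=O)c2ccccc2Cl)sc2c1CCN(C(=S)Nc1ccccc1F)C2`: 4970 nM
- Compound 2, `Cc1ccccc1NC(=S)N1CCc2c(sc(NC(=O)c3ccccc3Br)c2C(N)=O)C1`: > 50000 nM
- Compound 3, `NC(=O)c1c(NC(=O)c2ccccc2C(F)(F)F)sc2c1CCN(C(=S)Nc1ccccc1F)C2`: 23500 nM

In a functional assay on HL-60 cells (Homo sapiens) for antiproliferative activity, with a stated time of 24 h (a lower number here means a stronger inhibitor, a higher number a weaker inhibitor), compound 3 gives 23500 nM, the highest of the two numbers available, its nearest neighbour being compound 1 at 4970 nM. Going by the values given here, the one step that joins them, a 4.7-fold higher number from compound 1 to compound 3 (0.67 log units; beyond the scatter), is modest but beyond the scatter. Compound 2, which carries the methylphenyl group together with a bromo benzamide, reaches only the limit of this assay, (the limit of > 50000 nM in this assay, at which 1 of the 3 values shown sits), so its two differences from compound 1 cannot be separated into steps.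

Compound 4, `Cc1ccccc1NC(=S)N1CCc2c(sc(NC(=O)c3ccccc3C(F)(F)F)c2C(N)=O)C1`, is not yet measured. It differs from compound 3 by methyl in place of fluoro on an aromatic carbon. Among the compounds with values here, no measured step isolates this change; the only related evidence is that compound 2, the methylphenyl analogue, sits at the limit. The expectation for compound 4 is therefore a step of a 1.7-fold higher number from compound 3 to compound 4 (0.23 log units; within the scatter) in this assay, toward a weaker inhibitor or no change beyond the scatter. Compound 4 is estimated at 40000 nM, within 12000 nM to 130000 nM, with a real chance that only a limit is reported.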

Compound 4, half-maximal inhibitory concentration: 25100 nM
For compound 4 the middle estimate is 1.6-fold (0.20 log units) above the measured one, within the range that was stated.
By their numbers in this assay, from the lowest: compound 1; then compounds 3 and 4 (each within the scatter of the next). At a limit, above all of these: compound 2.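

In this assay, with trifluoromethyl held fixed, 2-fluorophenyl gives way to 2-methylphenyl with no change that can be told from the scatter: a 1.1-fold higher number from compound 3 to compound 4 (0.03 log units; within the scatter). The second new pair keeps 2-methylphenyl and exchanges bromo for trifluoromethyl, but the floor of its step, an at least 1.9-fold lower number from compound 2 to compound 4 (0.29 log units; that floor lies within the scatter), does not by itself show that these two groups differ. Compound 2 is held at a limit, not a number: the limit of > 50000 nM in this assay, at which 1 of the 4 values shown sits.

Still open, on these data alone, is whether the difference between chloro and trifluoromethyl seen with 2-fluorophenyl, a 4.7-fold higher number from compound 1 to compound 3 (0.67 log units; beyond the scatter), carries over to the 2-methylphenyl compounds. Also open, as far as these compounds go, is whether an amine or a methoxy group at this position on the aromatic ring would move the number beyond the scatter.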